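The compounds below may be only part of what the source reports. "The series", "measured", "known", "first", "only" and "open" are said of these compounds alone.

Three compounds have been measured so far:

Compound 1 `N=C(NCCCc1c[nH]cn1)NCCC(c1ccccc1)c1ccccn1` gives 1
Compound 2 `N=C(NCCCc1c[nH]cn1)NCCCC(c1ccccc1)c1ccccn1` gives 1
Compound 3 `N=C(NCCCc1c[nH]cn1)NCCC(c1ccc(Cl)c(Cl)c1)c1ccccn1` gives 1

All three were tested in an assay on cardiac atrium with histamine H2 receptor (Cavia porcellus) as the target; a lower number here means a smaller maximal response, a higher number a larger maximal response. In this assay compound 1 gives 1, compound 2 gives 1 and compound 3 gives 1. Each of them reaches the full response of the reference agonist, and the three values sit within the usual scatter of one another, so no order among them can be read.

Compound 1 and compound 3 share a core and differ in a single place: 3,4-dichlorophenyl in place of phenyl on a saturated chain carbon bound to an aromatic carbon and a saturated chain carbon. That change made the step of no change at the digits printed from compound 1 to compound 3 (within the scatter); the maximal response stayed where it was. Compound 2 has a different core, and how it differs from compound 1 is not broken down here.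

Compound 4 `N=C(NCCCc1c[nH]cn1)NCCCC(c1ccc(Cl)c(Cl)c1)c1ccccn1` has not yet been measured. It stands to compound 2 as compound 3 stands to compound 1: 3,4-dichlorophenyl in place of phenyl on a saturated chain carbon bound to an aromatic carbon and a saturated chain carbon. The place is the same in both pairs, word for word, so this is the same change, made a second time on a related core.

Because the earlier step of no change at the digits printed from compound 1 to compound 3 (within the scatter) showed no movement, and because compound 2 already gives 1 in this assay, the expected step from compound 2 to compound 4 is no change at the digits printed from compound 2 to compound 4 (within the scatter). Compound 4 is therefore estimated to give 1, with an expected range from 0.9 to 1.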

Compound 4, intrinsic activity: the largest response reached, as a fraction of the reference agonist's: 1
For compound 4 middle estimate and measured number coincide at the digits printed; the measured number falls inside the stated range.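

On the related core, replacing phenyl with 3,4-dichlorophenyl in this assay gives no change at the digits printed from compound 2 to compound 4 (within the scatter). Set beside the earlier step, the same replacement behaves alike on both cores, and the pair offers no sign that the core alters its effect on the maximal response: the same change on two cores in this assay, no change at the digits printed (within the scatter) from compound 1 to compound 3 and no change at the digits printed (within the scatter) from compound 2 to compound 4, 0 apart, within the scatter of two such steps. This shows only that, on these two cores, the largest response reached stays level with that of the reference agonist whether phenyl or 3,4-dichlorophenyl is present; it does not show that the agreement would hold on other cores, and it says nothing about how much compound is needed to reach that response, which this read-out does not capture.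

Going by these compounds, it remains open whether a methoxy group or an amine in place of the two chlorine atoms on the phenyl ring would also leave the maximal response where it stands. On these data alone, a longer chain between the guanidine-type centre and the carbon bearing the two aromatic rings is also open, and only a compound that falls short of the full response could show what, if anything, moves this read-out.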